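The compounds below may be only part of what the source reports. "The series", "measured", "known", "first", "only" and "open" are said of these compounds alone.

Measured so far in an assay on isolated protein for inhibition of protein deacetylase HDAC6 (Homo sapiens), read by fluorescence; on this read-out lower numbers stand for tighter binding and higher numbers for weaker binding:
compound 1, `CC(=O)Nc1ccc(NC(=O)C(F)(F)C(F)(F)C(F)(F)C(F)(F)C(F)(F)C(F)(F)C(=O)NO)cc1`, 9200 nM
compound 2, `O=C(NO)C(F)(F)C(F)(F)C(F)(F)C(F)(F)C(F)(F)C(F)(F)C(=O)Nc1ccc(I)cc1`, 4200 nM
compound 3, `O=C(NO)C(F)(F)C(F)(F)C(F)(F)C(F)(F)C(F)(F)C(F)(F)C(=O)Nc1nc(-c2ccccc2)cs1`, 5400 nM

The three share one core and differ only in the aryl group carried on the amide-type nitrogen. On this assay compound 3 sits close to both others: a 1.3-fold higher number from compound 2 to compound 3 (0.11 log units; within the scatter) and a 1.7-fold lower number from compound 1 to compound 3 (0.23 log units; within the scatter), each within the scatter. Going by the values given here, the only step beyond the scatter among the measured pairs is a 2.2-fold lower number from compound 1 to compound 2 (0.34 log units; beyond the scatter), and even that is modest.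

Compound 4, `O=C(NO)C(F)(F)C(F)(F)C(F)(F)C(F)(F)C(F)(F)C(F)(F)C(=O)Nc1cccc(-c2ccccc2)c1`, is the next variation at the same position: 3-phenylphenyl in place of 4-phenyl-1,3-thiazol-2-yl on an amide-type nitrogen. Among the compounds with values here, the steps that bear on it are the two earlier aryl swaps on the amide-type nitrogen, a 1.7-fold lower number from compound 1 to compound 3 (0.23 log units; within the scatter) and a 1.3-fold higher number from compound 2 to compound 3 (0.11 log units; within the scatter), neither of which moved beyond the scatter. Exchanging one aryl group for another at this nitrogen has so far left this assay essentially unchanged, so for compound 4 no step beyond the scatter is expected, in either direction. For compound 4 the estimate in this assay is 5000 nM. Its expected range runs from 2000 nM to 12000 nM. The expected step is a 1.1-fold lower number from compound 3 to compound 4 (0.03 log units; within the scatter).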

Compound 4, dissociation constant: 15000 nM
Compound 4: the middle estimate sits 3.0-fold (0.48 log units) below what was measured; measured number above the stated range.
By their numbers in this assay, from the lowest: compounds 2, 3, 1 and 4 (each within the scatter of the next, the first and the last beyond it).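

At the amide-type nitrogen, aryl exchange is not neutral in this assay: 3-phenylphenyl in place of 4-phenyl-1,3-thiazol-2-yl gives a 2.8-fold higher number from compound 3 to compound 4 (0.44 log units; beyond the scatter) and, in place of 4-iodophenyl, gives a 3.6-fold higher number from compound 2 to compound 4 (0.55 log units; beyond the scatter). Both steps are modest but beyond the scatter, so the flat picture at this position held only for the aryl swaps among compound 1, compound 2 and compound 3. Against 4-acetamidophenyl, the same change gives a 1.6-fold higher number from compound 1 to compound 4 (0.21 log units; within the scatter), so compound 4 does not stand apart from every other compound, and no evidence at hand accounts for the steps beyond the scatter.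

Still open, on these data alone, is whether an unsubstituted phenyl group, or a phenyl group carrying an amine or a carboxylic acid, would stay within the scatter of compound 2 and compound 3 or fall with compound 4 at this nitrogen. As far as these compounds go, it is also open whether these aryl steps would persist on a shorter or longer fluorinated chain in the shared core.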